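Swapping double-bond geometry in a cell-growth inhibition series

A few compounds are considered here, and "the series" means these few. Any claim that something is new, unique, unknown or untested is made for them only; others in the source may bear on it.

Of the compounds shown here, three share one core and have been tested in an ADME assay on WI-38 cells (Homo sapiens) for inhibition, read by CellTiter-Glo, with a stated time of 48 h, tested at 100 uM; on this read-out lower numbers stand for less inhibition and higher numbers for more inhibition at the one concentration tested (going by the name of the read-out). Compound 1 `CC(C)(CO)[C@@H](O)C(=O)N/C=C\C(=O)OCc1ccccc1` gives 4% in this assay. Compound 2 `CCOC(=O)/C=C/NC(=O)[C@@H](O)C(C)(C)CO` gives -6%. Compound 3 `CC(C)(CO)[C@H](O)C(=O)N/C=C\C(=O)OCc1ccccc1` gives -2%, the second highest of the three numbers, with compound 2 nearest and compound 1 furthest, both within the scatter of repeated measurements. Within the data shown here, the only step between two compounds that differ in a single place is a number 6 percentage points lower from compound 1 to compound 3 (within the scatter), and it says little more than that the two compounds are alike, because the fact that compounds 1 and 3 differ only in the configuration as drawn is the only thing that sets them apart.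

Compound 4 `CC(C)(CO)[C@H](O)C(=O)N/C=C/C(=O)OCc1ccccc1` has not yet been measured. Against compound 3 the change is the two compounds have the same atoms and bonds and differ only in configuration as drawn: 1 of 2 stereo elements differ; a double bond is drawn Z in compound 3 and E in compound 4. Among the measured compounds shown here, no measured step touches a double bond; the one measured step concerns a stereocentre and stayed inside the scatter. Taking that as the only guide, and noting that all three numbers sit close to zero, the expected step is a number 2 percentage points higher from compound 3 to compound 4 (within the scatter), that is, no movement beyond the scatter. Compound 4 is therefore estimated at 0% in this assay, with a likely range from -12% to 12%.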

Compound 4, a percentage reported as inhibition, at one concentration (the size of the read-out at that concentration, not a potency): 19%
Compound 4: middle estimate off by 19 percentage points, on the low side, outside the stated range (above it).
By their numbers in this assay, from the lowest: compounds 2, 3 and 1 (each within the scatter of the next); then compound 4.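

In this assay, among these compounds, turning the double bond from Z to E gives a number 21 percentage points higher from compound 3 to compound 4 (beyond the scatter) and is the first single change here to leave the scatter, whereas the stereocentre step did not; the rise can be put down to the double bond, because nothing else separates this pair: the fact that compounds 3 and 4 differ only in the configuration as drawn. Changing the stereocentre and the double bond together gives a number 15 percentage points higher from compound 1 to compound 4 (beyond the scatter) and so also leaves the scatter, which fits the same reading but cannot divide the effect between the two changes. The E double bond does not lift every compound, as compound 2 also carries it and still gives a number 25 percentage points higher from compound 2 to compound 4 (beyond the scatter) when phenyl stands in place of methyl, so the double bond goes with a higher number here only alongside the phenyl.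

On these data alone, whether the stereocentre matters once the double bond is E stays open, as does whether compound 2 would respond to the Z double bond in the same way. Also open, as far as these compounds go, is how the shared core would read with a carboxylic acid or a longer chain in place of the phenyl-bearing ester.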